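Secondary versus tertiary amines on the chain, antiproliferative series

The compounds below may be only part of what the source reports. "The series", "measured", "known", "first", "only" and "open" are said of these compounds alone.

Measured in a functional assay on MCF7 cells (Homo sapiens) for antiproliferative activity; a lower number here means a stronger inhibitor, a higher number a weaker inhibitor:
compound 1 `CC(C)=CCc1cc(C(=O)Nc2cc3ccc(OCCCN4CCCCC4)c(C)c3oc2=O)ccc1O`: limit, > 50000 nM
compound 2 `CCNCCCOc1ccc2cc(NC(=O)c3ccc(O)c(CC=C(C)C)c3)c(=O)oc2c1C`: 980 nM
compound 3 `CC(C)=CCc1cc(C(=O)Nc2cc3ccc(OCCCN(C)c4ccccc4)c(C)c3oc2=O)ccc1O`: limit, > 50000 nM

Compound 3 stands at a limit in this assay, > 50000 nM, and this is not a number. Compound 4 `CC(C)=CCc1cc(C(=O)Nc2cc3ccc(OCCCN[C@@H]4C[C@H]5CC[C@@H]4C5)c(C)c3oc2=O)ccc1O` differs from it as follows: a group of 8 heavy atoms (7 carbon, 1 nitrogen; 2 five-membered non-aromatic rings of carbon only) in place of a group of 8 heavy atoms (7 carbon, 1 nitrogen; one six-membered aromatic ring of carbon only), on a saturated chain carbon, three bonds along the chain from an oxygen on an aromatic ring. The entering group holds a hydrogen-bond donor, which methyl(phenyl)amino lacks and which ethylamino in compound 2 also holds.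

For the measured compounds named here, three measured steps bear on this change. The step of an at least 51-fold higher number from compound 2 to compound 3 (1.70 log units; beyond the scatter) is large, and so is an at least 51-fold lower number from compound 1 to compound 2 (1.70 log units; beyond the scatter). The step that the two limits leave unreadable from compound 1 to compound 3 cannot be read. Among these compounds, only compound 2 gives a number, 980 nM, and it carries ethylamino. Going by the values given here, no measured compound carries the entering group, so the expectation rests on this single comparison and stays wide. A large move towards a lower number is expected, estimated as an at least 12-fold lower number from compound 3 to compound 4 (1.09 log units; beyond the scatter), though a result at the limit remains possible. For compound 4 the expected value is 4000 nM, with an estimated range of 700 nM to 40000 nM.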

Compound 4, half-maximal inhibitory concentration: 1030 nM
For compound 4 the middle estimate is 3.9-fold (0.59 log units) above the measured one, and the stated range covers the measured number.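

In this assay, the group with 2 five-membered non-aromatic rings of carbon only, on the saturated chain carbon, gives a large change against methyl(phenyl)amino, an at least 48-fold lower number from compound 3 to compound 4 (1.68 log units; beyond the scatter), and against piperidin-1-yl, an at least 48-fold lower number from compound 1 to compound 4 (1.68 log units; beyond the scatter). Against ethylamino the step is a 1.1-fold higher number from compound 2 to compound 4 (0.02 log units; within the scatter), within the scatter, so a second secondary amine now gives a measured number, and the change on the amine nitrogen leaves these two compounds indistinguishable. The pattern now rests on two pairs, with no compound shown going against it: secondary amines in compound 2 and compound 4 give numbers, while the tertiary amines in compound 1 and compound 3 each stand at a limit, which is not a number: the limit of > 50000 nM in this assay, at which 2 of the 4 values shown sit.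

Going by these compounds, the step between compound 1 and compound 3 cannot be read, so any difference between those two tertiary amines stays unknown. On these data alone, whether the hydrogen-bond donor on the amine is what separates the two pairs also stays open, and a primary amine, a dimethylamino group or a longer chain at this place would bear on that.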